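Replacing the oxazole ring of compound 2

This account rests on a few compounds, and the source may have more. Where it says the series, first, only, none or still open, it means among the compounds named here.

Among the measured compounds shown here, in a physicochemical assay for solubility (on this read-out higher numbers stand for higher solubility and lower numbers for lower solubility), compound 1 (`Cc1nc(-c2cc(C(F)(F)F)ccc2[C@H]2CCOc3cc(S(=O)(=O)Nc4ncc(F)cn4)ccc32)co1`) gives 281000 nM and compound 2 (`Cc1nc(-c2cc(C(F)(F)F)ccc2[C@H]2CCOc3cc(S(=O)(=O)Nc4nccs4)ccc32)co1`) gives 61000 nM as the lower of the two numbers so far. Compound 3 (`O=C1COCCN1c1cc(C(F)(F)F)ccc1[C@H]1CCOc2cc(S(=O)(=O)Nc3nccs3)ccc21`) keeps the rest of compound 2 but carries 3-oxomorpholin-4-yl in place of 2-methyl-1,3-oxazol-4-yl on an aromatic carbon ortho to a large group (3-oxomorpholin-4-yl in place of 2-methyl-1,3-oxazol-4-yl on an aromatic carbon). For the measured compounds named here, the only measured step (a 4.6-fold lower number from compound 1 to compound 2 (0.66 log units; beyond the scatter)) changes the group on a sulfonamide nitrogen and not this place. Going by the values given here, it therefore sets no direction and serves only as a rough guide to size, and the data hold no direct precedent for the swap. On that guide, a modest rise is tentatively expected for compound 3 (a 2.1-fold higher number from compound 2 to compound 3 (0.33 log units; beyond the scatter)) and a fall cannot be excluded. Compound 3 is estimated to read 130000 nM with an expected range (40000 nM to 400000 nM).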

Compound 3, solubility: 695000 nM
Beside the measured number, compound 3's estimate is 5.3-fold (0.73 log units) below it, and the stated range ends below it.
By their numbers in this assay, from the lowest: compound 2; then compound 1; then compound 3.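

Putting 3-oxomorpholin-4-yl on this aromatic carbon gives an 11-fold higher number from compound 2 to compound 3 (1.06 log units; beyond the scatter) in this assay, which shows that this place, untouched by the earlier step, can move the read-out strongly and upward, whereas the modest change on the sulfonamide nitrogen, a 4.6-fold lower number from compound 1 to compound 2 (0.66 log units; beyond the scatter) in the same assay, went downward. The change replaces a five-membered aromatic ring with a six-membered non-aromatic ring carrying a double bond outside aromatic rings, while the hydrogen-bond donor and acceptor counts and the net charge stay the same, so those counts do not separate the two groups. Nothing measured here accounts for the rise.

Going by these compounds, it remains open whether a plain morpholin-4-yl without the carbonyl, or a piperidin-2-one ring, would read like 3-oxomorpholin-4-yl. On these data alone, it is also open whether the same rise would appear with 5-fluoropyrimidin-2-yl on the sulfonamide nitrogen.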